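Aryl swap on the five-membered ring: compound 3

A few compounds are considered here, and "the series" means these few. Any claim that something is new, unique, unknown or untested is made for them only; others in the source may bear on it.

Measured compounds:
compound 1 `c1ccc(-n2cc(COc3ccccc3-c3nc4ccccc4s3)nn2)cc1` with 26200 nM
compound 2 `Fc1ccccc1-c1cc(COc2ccccc2-c2nc3ccccc3s2)on1` with 23900 nM

In a functional assay on MCF7 cells (Homo sapiens) for cytotoxicity, read by MTT assay, with a stated time of 24 h (a higher number here means a weaker inhibitor, a lower number a stronger inhibitor), compound 1 gives 26200 nM and compound 2 gives 23900 nM. The two numbers lie within the scatter of each other, so compound 2 is not set apart from compound 1 on these data. Compound 3 `Cc1ccc(-c2cc(COc3ccccc3-c3nc4ccccc4s3)on2)cc1` carries 4-methylphenyl in place of 2-fluorophenyl on an aromatic carbon. Going by the values given here, no measured pair shows what this change does. The step from compound 2 to compound 3 is expected to be a 1.0-fold higher number from compound 2 to compound 3 (0.02 log units; within the scatter), none beyond the scatter in either direction. Compound 3 is expected to give 25000 nM, with a range from 10000 nM to 60000 nM.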

Compound 3, half-maximal inhibitory concentration: 27500 nM
Compound 3: middle estimate off by 1.1-fold (0.04 log units), on the low side, and the stated range covers the measured number.
By their numbers in this assay, from the lowest: compounds 2, 1 and 3 (each within the scatter of the next).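

In this assay, going by these compounds alone, putting 4-methylphenyl in place of 2-fluorophenyl on the aromatic carbon next to the ring nitrogen gives a 1.2-fold higher number from compound 2 to compound 3 (0.06 log units; within the scatter), the only step read so far at this position. On this step the position does not tell the two aryl groups apart, even though they differ in both substituent and its place on the phenyl ring. No measured evidence bears on this result.

The compounds shown have only these two aryl groups here. From the compounds shown here alone, whether a phenyl ring carrying an amine or a carboxylic acid, or a longer alkyl chain in place of the aryl group, would give a step beyond the scatter remains open.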